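Swapping an Aryl for a Second Piperidine on the Sulfonamide Core

A few compounds are considered here, and "the series" means these few. Any claim that something is new, unique, unknown or untested is made for them only; others in the source may bear on it.

Compound 1 `Cc1ccc(C2CCN(S(=O)(=O)c3c(C)cc(C)cc3C)CC2)cc1`: 2200 nM
Compound 2 `COc1cccc(S(=O)(=O)N2CCC(N3CCC(C)CC3)CC2)c1`: > 5000 nM

Among the compounds with values here, in a functional assay on DLD-1 cells (Homo sapiens) for antiproliferative activity, read by CellTiter-Glo, with a stated time of 72 h (a lower number here means a stronger inhibitor, a higher number a weaker inhibitor), compound 1 gives 2200 nM and is the only compound with a measured number. Compound 2 reaches only the limit of > 5000 nM in this assay, where no number is obtained (the limit of > 5000 nM in this assay, at which 1 of the 2 values shown sits). Compound 3 `Cc1cc(C)c(S(=O)(=O)N2CCC(N3CCC(C(C)C)CC3)CC2)c(C)c1` carries 4-isopropylpiperidin-1-yl in place of 4-methylphenyl on a saturated ring carbon. Within the data shown here, no measured step describes this change, so the expectation rests on the two values shown. Compound 3 is expected to be weaker than compound 1, with the step of a 2.0-fold higher number from compound 1 to compound 3 (0.31 log units; beyond the scatter) likely beyond the scatter, and may itself reach the limit. The estimate for compound 3 is 4500 nM, within a range from 1500 nM to 12000 nM.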

Compound 3, half-maximal inhibitory concentration: 0.3 nM
Estimate against measurement, compound 3: 15000-fold (4.18 log units) above, outside the stated range (below it).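

Putting 4-isopropylpiperidin-1-yl in place of 4-methylphenyl on a saturated ring carbon gives a 7300-fold lower number from compound 1 to compound 3 (3.87 log units; beyond the scatter) in this assay, so this position has a very strong hold on activity. The change also shows that an aromatic ring is not required here, since a non-aromatic ring containing nitrogen serves far better. Nothing measured here explains the size of this step.

On these data alone, whether the gain comes from the ring nitrogen or from the isopropyl group remains open. An unsubstituted piperidine ring, or a cyclohexyl ring carrying the same isopropyl, would separate the two.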